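A few compounds are considered here, and "the series" means these few. Any claim that something is new, unique, unknown or untested is made for them only; others in the source may bear on it.

Measured compounds:
compound 1 `CC(C)CS(=O)(=O)N[C@@H](CNC(=O)c1ccc2c(c1)C(=O)N(CCC1CCNCC1)C2)C(=O)O`: 9 nM
compound 2 `CCOCCS(=O)(=O)N[C@@H](CNC(=O)c1ccc2c(c1)C(=O)N(CCC1CCNCC1)C2)C(=O)O`: 8 nM
compound 3 `O=C(NC[C@H](NS(=O)(=O)c1cccnc1)C(=O)O)c1ccc2c(c1)C(=O)N(CCC1CCNCC1)C2`: 15 nM

In a functional assay for inhibition, with Homo sapiens as the target (on this read-out lower numbers stand for stronger inhibition and higher numbers for weaker inhibition), compound 1 gives 9 nM, the second highest of the three numbers; the nearest is a 1.1-fold lower number from compound 1 to compound 2 (0.05 log units; within the scatter) and the furthest is a 1.7-fold higher number from compound 1 to compound 3 (0.22 log units; within the scatter), both within the scatter. Compound 4 `O=C(O)c1ccc(S(=O)(=O)N[C@@H](CNC(=O)c2ccc3c(c2)C(=O)N(CCC2CCNCC2)C3)C(=O)O)cc1` has not been measured. It differs from compound 1 in one place: 4-carboxyphenyl in place of isobutyl on a sulfonyl sulfur. Among the measured compounds shown here, the steps that bear on this change are the two that put an aromatic ring on the sulfonyl sulfur, a 1.7-fold higher number from compound 1 to compound 3 (0.22 log units; within the scatter) and a 1.9-fold higher number from compound 2 to compound 3 (0.27 log units; within the scatter), each within the scatter. Compound 4 is therefore expected to show a 1.8-fold higher number from compound 1 to compound 4 (0.25 log units; within the scatter), a step of roughly the size seen for compound 3 and not clearly beyond the scatter. Compound 4 is estimated at 16 nM, with a range from 6 nM to 45 nM.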

Compound 4, half-maximal inhibitory concentration: 7 nM
Beside the measured number, compound 4's estimate is 2.3-fold (0.36 log units) above it; low and high end bracket the measured number.
By their numbers in this assay, from the lowest: compounds 4, 2, 1 and 3 (each within the scatter of the next, the first and the last beyond it).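

In this assay, 4-carboxyphenyl on the sulfonyl sulfur cannot be told apart from isobutyl, a 1.3-fold lower number from compound 1 to compound 4 (0.11 log units; within the scatter), or from 2-ethoxyethyl, a 1.1-fold lower number from compound 2 to compound 4 (0.06 log units; within the scatter), so this larger aromatic group is tolerated here. Against pyridin-3-yl, however, it gives the first step at this position beyond the scatter, though a modest one, a 2.1-fold lower number from compound 3 to compound 4 (0.33 log units; beyond the scatter), showing that the choice of aromatic group can shift the number. No measurement offered here accounts for that difference. Whether the carboxylic acid contributes stays open, since the compounds shown include no plain phenyl group, methyl ester or amine in its place.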